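Dihydroxypropyl Side Chain and Cell Toxicity Expectation

The source may hold more compounds than are shown below. What is called first, only, known or untested is meant among the compounds shown, and "the series" means these compounds.

Compound 1 `CCCNc1cc(Oc2c(OC)cc3cc(C#N)ccc3c2OC)nc(Nc2ccc(C#N)cc2)n1`: > 125000 nM, a limit of the assay
Compound 2 `CCCCCC(C)Nc1cc(Oc2c(OC)cc3cc(C#N)ccc3c2OC)nc(Nc2ccc(C#N)cc2)n1`: > 125000 nM, a limit of the assay
Compound 3 `COc1cc2cc(C#N)ccc2c(OC)c1Oc1cc(NCCCOC(C)C)nc(Nc2ccc(C#N)cc2)n1`: > 125000 nM, a limit of the assay

The three measured compounds share one core and differ only in the group on a nitrogen on an aromatic ring. In an ADME assay on MT4 cells (Homo sapiens) for cytotoxicity, read by MTT assay, with a stated time of 5 days (on this read-out higher numbers stand for lower toxicity in this test and lower numbers for higher toxicity in this test), none of them gave a number: every value is a limit, so compound 3 stands at the same limit as the other two (the limit of > 125000 nM in this assay, at which 3 of the 3 values shown sit). For that reason the steps among them carry no readable size: a step that the two limits leave unreadable from compound 1 to compound 2, a step that the two limits leave unreadable from compound 1 to compound 3 and a step that the two limits leave unreadable from compound 2 to compound 3.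

Compound 4 `COc1cc2cc(C#N)ccc2c(OC)c1Oc1cc(NCC(O)CO)nc(Nc2ccc(C#N)cc2)n1` differs from compound 3 by 1,2-dihydroxyethyl in place of 2-isopropoxyethyl on a saturated chain carbon bound to a nitrogen on an aromatic ring. Among the measured compounds shown here, no measured step bears readably on this change, and no step has left the limit, so no step beyond the scatter is expected in this assay; the likeliest outcome is another limit. The expected step from compound 3 to compound 4 is a step that the limit leaves unreadable from compound 3 to compound 4. Compound 4 is therefore estimated at about 150000 nM, within a range from 90000 nM to 300000 nM.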

Compound 4, half-maximal cytotoxic concentration: 29500 nM
Compound 4: the middle estimate sits 5.1-fold (0.71 log units) above what was measured, outside the stated range (below it).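

The side chain on this nitrogen is not silent in this assay: 2,3-dihydroxypropyl gives the first value below the limit, and a lower number here stands for higher toxicity in this test. Measured against 3-isopropoxypropyl, the change gives a clear drop (an at least 4.2-fold lower number from compound 3 to compound 4 (0.62 log units; beyond the scatter)), and the comparisons with 1-methylhexyl (an at least 4.2-fold lower number from compound 2 to compound 4 (0.62 log units; beyond the scatter)) and with propyl (an at least 4.2-fold lower number from compound 1 to compound 4 (0.62 log units; beyond the scatter)) point the same way. Among these four compounds, the only group with hydrogen-bond donors on the chain is also the only one that leaves the limit, so a plain chain, a branched chain and an ether chain all differ from it in this test.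

From the compounds shown here alone, whether a single hydroxyl group, as in 3-hydroxypropyl, would be enough remains open. So does the outcome with an amine or a carboxylic acid at the end of the chain.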